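Azidoethyl in place of cyclopropylmethyl on the hexyl core

A few compounds are considered here, and "the series" means these few. Any claim that something is new, unique, unknown or untested is made for them only; others in the source may bear on it.

Among the measured compounds shown here, in an ADME assay on MCF7 cells (Homo sapiens) for cytotoxicity, read by MTT assay, with a stated time of 11 days (on this read-out higher numbers stand for weaker inhibition of growth and lower numbers for stronger inhibition of growth), compound 2 `CCCCCCc1cc2c(=O)n(CC3CC3)cnc2s1` is the only compound to give a number, 24.8 ug/mL. Compound 1 `CCCCCc1cc2c(=O)n(CC3CC3)cnc2s1` reports only a limit of the assay, > 100 ug/mL. Compound 3 `CCCCCCCc1cc2c(=O)n(CC3CC3)cnc2s1` likewise reports only a limit, > 100 ug/mL. The two chain steps, an at least 4.0-fold lower number from compound 1 to compound 2 (0.60 log units; beyond the scatter) and an at least 4.0-fold higher number from compound 2 to compound 3 (0.60 log units; beyond the scatter), both run against (the limit of > 100 ug/mL in this assay, at which 2 of the 3 values shown sit). Compound 4 `CCCCCCc1cc2c(=O)n(CCN=[N+]=[N-])cnc2s1` keeps the hexyl chain of compound 2 and alters only the group on the aromatic nitrogen: azidomethyl in place of cyclopropyl on a saturated chain carbon bound to an aromatic nitrogen. For the measured compounds named here, no measured step touches that place; all of them alter the chain, so no size can be read from them for this change. Compound 4 is therefore expected to stay within the scatter of compound 2, with a 1.2-fold higher number from compound 2 to compound 4 (0.08 log units; within the scatter). The estimate for compound 4 is 30 ug/mL, between 10 ug/mL and 100 ug/mL.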

Compound 4, concentration for 50% growth inhibition: > 100 ug/mL
Compound 4 was reported as a limit (the forecaster's own chance of this, stated with the estimate: 35%); at least 3.3-fold (0.52 log units) between middle value and limit.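

Azidomethyl in place of cyclopropyl on a saturated chain carbon bound to an aromatic nitrogen gives an at least 4.0-fold higher number from compound 2 to compound 4 (0.60 log units; beyond the scatter) in this assay. This first step away from the chain shows that keeping the hexyl chain does not by itself keep the number of compound 2. Compound 4 gives only a limit of the assay, so the full size of the step stays unread: the limit of > 100 ug/mL in this assay, at which 3 of the 4 values shown sit.

Going by these compounds, whether the higher number follows the loss of the cyclopropyl ring or the entry of azidomethyl stays open. Also open, on these data alone, is how a plain propyl or an amine at this place would read.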